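A Pyridyl Piperazine in Place of a Pyrrolidine

The source may hold more compounds than are shown below. What is called first, only, known or untested is meant among the compounds shown, and "the series" means these compounds.

For the measured compounds named here, compound 3 `Cc1cc(Cl)ccc1NC(=O)Nc1nc(Sc2c[nH]c3ccccc23)cc(N2CCCC2)n1` holds the lowest of the three numbers so far in a functional assay on PC-3 cells (Homo sapiens) for inhibition, with a stated time of 72 h (on this read-out higher numbers stand for weaker inhibition and lower numbers for stronger inhibition), where compound 3 gives 12900 nM. Compound 2 `O=C(Nc1ccccc1)Nc1nc(Sc2c[nH]c3ccccc23)cc(N2CCN(c3ccccn3)CC2)n1` gives 21600 nM and compound 1 `Cc1cc(Cl)ccc1NC(=O)Nc1nc(Sc2c[nH]c3ccccc23)cc(N2CCN(Cc3ccccc3)CC2)n1` gives 22500 nM; both gaps to compound 3 lie within the usual scatter, so the three compounds cannot be told apart on this read-out. Compound 4 `Cc1cc(Cl)ccc1NC(=O)Nc1nc(Sc2c[nH]c3ccccc23)cc(N2CCN(c3ccccn3)CC2)n1` differs from compound 3 only in 4-(pyridin-2-yl)piperazin-1-yl in place of pyrrolidin-1-yl on an aromatic carbon. Going by the values given here, no measured pair shows this exact change, but compound 2 already carries the entering group and reads 21600 nM, close to compound 3. On that basis the expected step is a 1.4-fold higher number from compound 3 to compound 4 (0.14 log units; within the scatter), with no direction beyond the scatter. Compound 4 is estimated at 18000 nM, within a range from 8000 nM to 45000 nM.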

Compound 4, half-maximal inhibitory concentration: 19800 nM
Compound 4: middle estimate off by 1.1-fold (0.04 log units), on the low side; low and high end bracket the measured number.
By their numbers in this assay, from the lowest: compounds 3, 4, 2 and 1 (each within the scatter of the next).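

In this assay, putting 4-(pyridin-2-yl)piperazin-1-yl in place of pyrrolidin-1-yl on this aromatic carbon gives a 1.5-fold higher number from compound 3 to compound 4 (0.19 log units; within the scatter) and so does not separate the two compounds. The neighbouring changes also stay within the scatter: 4-chloro-2-methylphenyl in place of phenyl on an amide-type nitrogen gives a 1.1-fold lower number from compound 2 to compound 4 (0.04 log units; within the scatter) and pyridin-2-yl in place of benzyl on an amine nitrogen in a ring gives a 1.1-fold lower number from compound 1 to compound 4 (0.06 log units; within the scatter) on the same read-out. Nothing available here offers a reason for these steps.

Still open, going by these compounds, is whether a smaller group at this carbon, such as dimethylamino or morpholin-4-yl, would move the number beyond the scatter. Also open, on these data alone, is whether a carboxylic acid on the pyridine ring would do so.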